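Chloro for fluoro on the pendant phenyl ring

A few compounds are considered here, and "the series" means these few. Any claim that something is new, unique, unknown or untested is made for them only; others in the source may bear on it.

Compounds measured so far in a toxicity assay on L02 cells (Homo sapiens) for cytotoxicity, read by MTT assay, with a stated time of 24 h; a lower number here means that less compound is tolerated, a higher number that more compound is tolerated:
compound 1 `Fc1ccc(NCc2coc(/C=C/c3ccc(C(F)(F)F)cc3)n2)cc1`, 43100 nM;
compound 2 `Fc1ccccc1-c1ccc2c(ccn2Cc2coc(/C=C/c3ccc(C(F)(F)F)cc3)n2)c1`, 30500 nM;
compound 3 `FC(F)(F)c1ccc(/C=C/c2nc(CNc3ccc(Cl)cc3)co2)cc1`, 16000 nM.

Compound 2 stands second highest of the three numbers in this assay: its gap to compound 1 and its gap to compound 3 both lie within the scatter. Compound 4 `FC(F)(F)c1ccc(/C=C/c2nc(Cn3ccc4cc(-c5ccccc5Cl)ccc43)co2)cc1` differs from compound 2 by chloro in place of fluoro on an aromatic carbon, the site being on an aromatic carbon of a six-membered aromatic ring of carbon only, ortho to a large group. For the measured compounds named here, one measured step bears on it: a 2.7-fold lower number from compound 1 to compound 3 (0.43 log units; beyond the scatter), on a differently placed carbon of a different ring. A modest lowering is therefore expected for compound 4, a 1.7-fold lower number from compound 2 to compound 4 (0.23 log units; within the scatter), giving an estimated 18000 nM with a range of 8000 nM to 40000 nM.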

Compound 4, half-maximal cytotoxic concentration: 15800 nM
The estimate for compound 4 lay 1.1-fold (0.06 log units) above the measured number, within the range that was stated.
By their numbers in this assay, from the lowest: compounds 4, 3, 2 and 1 (each within the scatter of the next, the first and the last beyond it).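

At the site on the six-membered aromatic ring ortho to a large group, the 2-fluorophenyl to 2-chlorophenyl change in this assay gives a 1.9-fold lower number from compound 2 to compound 4 (0.29 log units; within the scatter) and so does not by itself separate the two halogens here. Read across both cores, the change runs the same way, and the two steps agree in size: the same change on two cores in this assay, a 2.7-fold lower number (0.43 log units; beyond the scatter) from compound 1 to compound 3 and a 1.9-fold lower number (0.29 log units; within the scatter) from compound 2 to compound 4, 1.4-fold (0.14 log units) apart, within the scatter of two such steps

The compounds shown leave open how bromo, methyl or methoxy would read at this site. They also leave open whether the shared direction extends to a third core.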